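The compounds below may be only part of what the source reports. "The series", "measured", "known", "first", "only" and "open" are said of these compounds alone.

Of the compounds shown here, three have been measured in a functional assay on the whole organism (Ear, strain ICR) for inhibition, with Mus musculus as the target, with stated times of 30 min and 2 h, at a dose of 10 umol/kg by the oral route; on this read-out higher numbers stand for more inhibition at the one dose given (going by the name of the read-out) and lower numbers for less inhibition. Compound 1, `CC[C@H](C)[C@H](NCCC1OCC(C)(C)CO1)C(=O)N[C@H]1[C@@H](OCc2ccccc2)O[C@H](COCc2ccccc2)[C@@H](OCc2ccccc2)[C@@H]1OCc1ccccc1`, gives 81.6%. Compound 2, `CC(=O)OC[C@H]1O[C@H](OC(C)=O)[C@H](NC(=O)[C@H](C)NCCC2OCC(C)(C)CO2)[C@@H](OC(C)=O)[C@@H]1OC(C)=O`, gives 84.2%. Compound 3, `CC[C@H](C)[C@H](NCCC1OCC(C)(C)CO1)C(=O)N[C@H]1C(O)O[C@H](CO)[C@@H](O)[C@@H]1O`, gives 88.7%. Compound 3 sits at the top of these three numbers, yet compound 2 and compound 1 both lie within the usual scatter of it, so the three cannot be told apart. Compound 4, `CC(C)C[C@H](NCCC1OCC(C)(C)CO1)C(=O)N[C@H]1C(O)O[C@H](CO)[C@@H](O)[C@@H]1O`, has not been measured in this assay. Its structure differs from compound 3 by isobutyl in place of sec-butyl on a saturated chain carbon bound to an amine nitrogen and a carbonyl carbon. Among the compounds with values here, nothing among the measured compounds shows how such a swap acts, so a step in this assay no larger than the scatter is expected, in no particular direction. The expected step is a number 2.7 percentage points lower from compound 3 to compound 4 (within the scatter). Compound 4 is estimated at 86%, within a range from 70% to 95%.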

Compound 4, a percentage reported as inhibition, in the whole organism at one dose (the size of the read-out at that dose, not a potency): 81.8%
Beside the measured number, compound 4's estimate is 4.2 percentage points above it, and the stated range covers the measured number.
By their numbers in this assay, from the lowest: compounds 1, 4, 2 and 3 (each within the scatter of the next).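

Swapping sec-butyl for isobutyl on a saturated chain carbon bound to an amine nitrogen and a carbonyl carbon gives, in this assay, a number 6.9 percentage points lower from compound 3 to compound 4 (within the scatter) as the first direct comparison at this position. This rearrangement of the same atoms, which also removes a defined stereocentre from the group, therefore gives two compounds that cannot be told apart. No measurement available here accounts for the result. Still open, from the compounds shown here alone, is how a different group at this position, such as an amine, a carboxylic acid or a longer chain, would read in this assay.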